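From Nitrophenyl Ketone to Aldehyde on a Shared Core

The compounds below may be only part of what the source reports. "The series", "measured", "known", "first", "only" and "open" are said of these compounds alone.

Of the compounds shown here, two on a shared core have been measured in a functional assay (aorta) with Rattus norvegicus as the target; on this read-out higher numbers stand for higher potency (the scale is a negative logarithm) and lower numbers for lower potency. Compound 1 `CC(=O)c1ccc2c(c1)C(n1ccccc1=O)=CC(C)(C)O2` gives 7.37, while compound 2 `CC1(C)C=C(n2ccccc2=O)c2cc(C(=O)c3ccc([N+](=O)[O-])cc3)ccc2O1` gives 6.2, the lower of the two numbers, and the step of a number 1.17 log units lower from compound 1 to compound 2 (beyond the scatter) is large.

Compound 3 `CC1(C)C=C(n2ccccc2=O)c2cc(C=O)ccc2O1` differs from compound 2 in one place: hydrogen in place of 4-nitrophenyl on a carbonyl carbon. Among the compounds with values here, the only measured step that bears on this change is the one that introduced the same group: a number 1.17 log units lower from compound 1 to compound 2 (beyond the scatter) records what happened when 4-nitrophenyl took the place of methyl on the carbonyl carbon. Removing that 4-nitrophenyl again, leaving hydrogen, is therefore expected to recover much of the lost potency, although hydrogen is not methyl and the recovery may be incomplete. In this assay the step of a number 1.00 log units higher from compound 2 to compound 3 (beyond the scatter) is expected to be upward and beyond the scatter. Compound 3 is estimated at 7.2, with a range from 6.5 to 7.8.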

Compound 3, logarithm of the reciprocal of the active concentration, log(1/C): 6.91
The estimate for compound 3 lay 0.29 log units above the measured number; low and high end bracket the measured number.
By their numbers in this assay, from the lowest: compound 2; then compound 3; then compound 1.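

With hydrogen on the carbonyl carbon, this assay records a number 0.71 log units higher from compound 2 to compound 3 (beyond the scatter), so removing 4-nitrophenyl restores only part of the drop seen when that group replaced methyl. The comparison with methyl, which the earlier compounds could not offer, is a number 0.46 log units lower from compound 1 to compound 3 (beyond the scatter): among these three groups on the carbonyl carbon, methyl gives the highest number, hydrogen the middle one and 4-nitrophenyl the lowest, so the order does not follow the count of heavy atoms in the group. Nothing available here explains this order.

As far as these compounds go, it remains open whether a longer chain such as ethyl, or an amine or hydroxyl on the same carbonyl carbon, would match or exceed methyl. From the compounds shown here alone, it is also open whether the low number of compound 2 belongs to the aromatic ring or to its nitro group, a question that plain phenyl at this place could address.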